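Chain extension on the sulfonamide of compound 1

The compounds below may be only part of what the source reports. "The series", "measured", "known", "first", "only" and "open" are said of these compounds alone.

Compound 1 `CCCS(=O)(=O)Nc1ccc(F)c(C(=O)c2n[nH]c3ncc(-c4ccc(S(N)(=O)=O)cc4)cc23)c1F` is the reference point of this set. In an assay for binding affinity to dual specificity mitogen-activated protein kinase kinase 4 (Homo sapiens), read by KINOMEscan, tested at 10 nM (a higher number here means a weaker effect of the compound at the concentration tested, a lower number a stronger effect), compound 1 gives 5.1%, the highest of the three numbers in hand, though within the scatter of both others: compound 3 `CCCS(=O)(=O)Nc1ccc(F)c(C(=O)c2n[nH]c3ncc(-c4ccc(C(N)=O)cc4)cc23)c1F` gives 4% and compound 2 `CCCS(=O)(=O)Nc1ccc(F)c(C(=O)c2n[nH]c3ncc(-c4ccc(-c5nnn[nH]5)cc4)cc23)c1F` gives 1.1%. The steps among them, a number 4 percentage points lower from compound 1 to compound 2 (within the scatter), a number 1.1 percentage points lower from compound 1 to compound 3 (within the scatter) and a number 2.9 percentage points higher from compound 2 to compound 3 (within the scatter), each swap the group on the aromatic carbon and none of them moves the read-out beyond the scatter.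

Compound 4 `CCCCS(=O)(=O)Nc1ccc(F)c(C(=O)c2n[nH]c3ncc(-c4ccc(S(N)(=O)=O)cc4)cc23)c1F` differs from compound 1 by methyl in place of hydrogen on a saturated chain carbon, three bonds along the chain from a sulfonyl sulfur, that is propyl to butyl, three bonds along the chain from a sulfonyl sulfur. For the measured compounds named here, no measured step touches this chain, so nothing in hand speaks directly for or against an effect; the measured steps show only that the read-out has not moved beyond the scatter for any change tried so far. The expectation is therefore a step of about a number 0.1 percentage points lower from compound 1 to compound 4 (within the scatter), nothing beyond the scatter. Compound 4 is estimated at 5%, with a range from 1% to 12%.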

Compound 4, a percentage reported as activity, at one concentration (the size of the read-out at that concentration, not a potency): 6.9%
The estimate for compound 4 lay 1.9 percentage points below the measured number; the range from low to high includes it.
By their numbers in this assay, from the lowest: compounds 2, 3, 1 and 4 (each within the scatter of the next).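

Propyl to butyl is the first change shown on the sulfonyl chain, and in this assay it gives a number 1.8 percentage points higher from compound 1 to compound 4 (within the scatter) for methyl in place of hydrogen at this position. For the compounds shown here, the sulfonyl chain, untouched among the earlier compounds, can therefore carry butyl with the read-out still within the scatter of compound 1, so the lack of a measurable step now extends from the group on the aromatic carbon to this chain. The data in hand offer no evidence bearing on this result.

On these data alone, whether a shorter ethyl chain, a longer hexyl chain or a terminal amine on the chain would shift the read-out beyond the scatter remains open. Also open, as far as these compounds go, is whether butyl behaves the same way when 1H-tetrazol-5-yl or carbamoyl replaces sulfamoyl on the aromatic carbon.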